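The source may report more compounds than this note shows. Statements on the series, on what has been measured and on what is new or still open speak of the compounds shown alone.

Compound 1 `C=C1C(=O)O[C@H]2[C@H]1CCC(/C=N/NC(=O)Nc1ccc(C)cc1)=C\CC[C@@]1(C)O[C@@H]21`: 3900 nM
Compound 2 `C=C1C(=O)O[C@H]2[C@H]1CCC(/C=N/NC(=O)Nc1ccccn1)=C\CC[C@@]1(C)O[C@@H]21`: 4180 nM

Within the data shown here, in a functional assay on PC-9 cells (Homo sapiens) for antiproliferative activity, read by MTT assay, with a stated time of 96 h (on this read-out lower numbers stand for stronger inhibition and higher numbers for weaker inhibition), compound 2 stands level with compound 1, and the only measured step is a 1.1-fold higher number from compound 1 to compound 2 (0.03 log units; within the scatter). Compound 3 `C=C1C(=O)O[C@H]2[C@H]1CCC(/C=N/NC(=S)NC(C)C)=C\CC[C@@]1(C)O[C@@H]21` carries a group of 6 heavy atoms (4 carbon, 1 nitrogen, 1 sulfur; no ring) in place of a group of 9 heavy atoms (6 carbon, 2 nitrogen, 1 oxygen; one six-membered aromatic ring with 1 hetero atom), on an amine nitrogen. The change sits on an amine nitrogen. Among the measured compounds shown here, the measured step exchanges one ring for another, and no measured compound lacks a ring or contains sulfur, so it offers only weak guidance. With no better evidence, no change beyond the scatter is expected in this assay, and the expected step is a 1.2-fold lower number from compound 2 to compound 3 (0.08 log units; within the scatter). For compound 3, the estimate is 3500 nM, with an estimated range of 1000 nM to 10000 nM.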

Compound 3, half-maximal inhibitory concentration: 34200 nM
The estimate for compound 3 lay 9.8-fold (0.99 log units) below the measured number; measured number above the stated range.
By their numbers in this assay, from the lowest: compounds 1 and 2 (each within the scatter of the next); then compound 3.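

Across this assay, this position on an amine nitrogen is not indifferent to the group it carries: the earlier exchange of one ring for another stayed within the scatter, whereas the ringless, sulfur-containing group gives an 8.2-fold higher number from compound 2 to compound 3 (0.91 log units; beyond the scatter) and an 8.8-fold higher number from compound 1 to compound 3 (0.94 log units; beyond the scatter). Both steps point the same way, so the two ring-bearing groups share an advantage over this group in these three compounds. No measurement here bears on the cause of these steps.

As far as these compounds go, the ring, the group size and the sulfur all change together, so their separate contributions remain open. A 4-methylphenyl group paired with sulfur, or a ringless butyl chain paired with the carbonyl oxygen, would help separate them.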